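Adding One Methyl to Compound 2

This account rests on a few compounds, and the source may have more. Where it says the series, first, only, none or still open, it means among the compounds named here.

In a functional assay on PANC-1 cells (Homo sapiens) for antiproliferative activity, read by sulforhodamine B assay, with a stated time of 48 h (a lower number here means a stronger inhibitor of growth, a higher number a weaker inhibitor of growth), compound 1 (`ClC1=C(c2nnc(-c3cccc(I)c3)o2)CCCc2ccccc21`) gives 2370 nM and compound 2 (`Cc1cc2c(cc1C)C(Cl)=C(c1nnc(-c3ccccc3)o1)CCC2`) gives 4120 nM. These two numbers lie within the usual scatter of each other, so compound 2 cannot be ranked against compound 1. Compound 3 (`Cc1ccc(-c2nnc(C3=C(Cl)c4cc(C)c(C)cc4CCC3)o2)cc1`) has methyl in place of hydrogen on an aromatic carbon of compound 2: methyl in place of hydrogen on an aromatic carbon. Among the compounds with values here, no measured pair shows this change, so the expectation is cautious. The expected step, a 1.2-fold lower number from compound 2 to compound 3 (0.07 log units; within the scatter), stays within the scatter of this assay, with no clear direction. For compound 3 the estimated value is 3500 nM, with an expected range from 1500 nM to 8000 nM.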

Compound 3, concentration for 50% growth inhibition: 3880 nM
Estimate against measurement, compound 3: 1.1-fold (0.04 log units) below, within the range that was stated.
By their numbers in this assay, from the lowest: compounds 1, 3 and 2 (each within the scatter of the next).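

In this assay the change from phenyl to 4-methylphenyl, para to a large group, gives a 1.1-fold lower number from compound 2 to compound 3 (0.03 log units; within the scatter) and so lies within the scatter. This first direct test of the position shows that one added methyl there leaves compound 2 and compound 3 indistinguishable in this assay. Nothing available offers an explanation for this result.

On these data alone, whether this position responds to other groups stays open: an amine or a carboxylic acid in place of the methyl could give a different result. As far as these compounds go, a longer chain, such as ethyl or propyl, remains equally open.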